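The source may report more compounds than this note shows. Statements on the series, on what has been measured and on what is new or still open speak of the compounds shown alone.

Three compounds have been measured in an assay on membranes from CHO cells for displacement of a labelled ligand from adenosine receptor A1 (Homo sapiens), read by scintillation counting, with a stated time of 60 min, tested at 1 uM; on this read-out higher numbers stand for more inhibition at the one concentration tested (going by the name of the read-out) and lower numbers for less inhibition:
compound 1, `CC1=C(C(=O)NC(C)C)C(c2ccsc2)NC(=O)N1`, gives 8%
compound 2, `CC1=C(C(=O)SC(C)C)C(c2ccsc2)NC(=O)N1`, gives 24%
compound 3, `CCC(C)OC(=O)C1=C(C)NC(=O)NC1c1ccsc1`, gives 5%

Compound 3 stands lowest of the three numbers. Its nearest neighbour is compound 1, with a number 3 percentage points lower from compound 1 to compound 3 (within the scatter), and the furthest is compound 2, with a number 19 percentage points lower from compound 2 to compound 3 (beyond the scatter). Compound 4, `CC1=C(C(=O)OCC2CC2)C(c2ccsc2)NC(=O)N1`, has not yet been measured. It differs from compound 3 in one place: cyclopropylmethyl in place of sec-butyl on an oxygen next to a carbonyl group. All measured steps change the group attached to the carbonyl carbon itself, as in a number 16 percentage points higher from compound 1 to compound 2 (beyond the scatter), and none swaps one alkyl group for another on the oxygen next to a carbonyl group. So no measured step bears directly on the change from compound 3 to compound 4, and the only guide is that compound 3, the one compound carrying an oxygen next to a carbonyl group, gives the lowest number. Compound 4 is therefore expected to stay close to compound 3, with a step of a number 2 percentage points higher from compound 3 to compound 4 (within the scatter), within the scatter. The estimate for compound 4 is 7%, between 0% and 18%.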

Compound 4, a percentage reported as inhibition, at one concentration (the size of the read-out at that concentration, not a potency): 39%
Estimate against measurement, compound 4: 32 percentage points below; measured number outside the range, above it.
By their numbers in this assay, from the lowest: compounds 3 and 1 (each within the scatter of the next); then compound 2; then compound 4.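

In this assay, among these compounds, the group on the oxygen next to a carbonyl group matters a great deal: cyclopropylmethyl in place of sec-butyl, with the same count of heavy atoms, gives a number 34 percentage points higher from compound 3 to compound 4 (beyond the scatter) and so opens a position that no earlier step had touched. The oxygen link alone therefore does not hold the number down, as compound 3 had suggested, since cyclopropylmethoxy on the carbonyl carbon gives both a number 15 percentage points higher from compound 2 to compound 4 (beyond the scatter) and a number 31 percentage points higher from compound 1 to compound 4 (beyond the scatter). Nothing measured here gives a reason for these steps.

Going by these compounds, whether the three-membered ring itself matters stays open, and an n-butyl or cyclobutylmethyl group on the same oxygen would test that. Also open, on these data alone, is whether cyclopropylmethylamino or cyclopropylmethylsulfanyl on the carbonyl carbon would follow cyclopropylmethoxy.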